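Adding a Fluoro to the Bromophenyl Ring of Compound 3

This account rests on a few compounds, and the source may have more. Where it says the series, first, only, none or still open, it means among the compounds named here.

Going by the values given here, compound 3 `Cn1ccc2c(Oc3ccc(NC(=O)c4cc5cccnc5n(-c5ccc(Br)cc5)c4=O)cc3)ccnc21` gives 680 nM in a functional assay on A549 cells (Homo sapiens) for antiproliferative activity, read by MTT assay, with a stated time of 72 h (a lower number here means a stronger inhibitor, a higher number a weaker inhibitor), the highest of the three numbers measured so far. Compound 2 `Cn1ccc2c(Oc3ccc(NC(=O)c4cc5cccnc5n(-c5ccc(Cl)cc5)c4=O)cc3)ccnc21` gives 630 nM and compound 1 `Cn1ccc2c(Oc3ccc(NC(=O)c4cc5cccnc5n(-c5ccc(F)cc5)c4=O)cc3)ccnc21` gives 210 nM. Swapping the halogen gave modest steps, a 3.0-fold higher number from compound 1 to compound 2 (0.48 log units; beyond the scatter) and a 3.2-fold higher number from compound 1 to compound 3 (0.51 log units; beyond the scatter), while a 1.1-fold higher number from compound 2 to compound 3 (0.03 log units; within the scatter) stayed within the scatter. Compound 4 `Cn1ccc2c(Oc3ccc(NC(=O)c4cc5cccnc5n(-c5ccc(Br)cc5F)c4=O)cc3)ccnc21` differs from compound 3 by fluoro in place of hydrogen on an aromatic carbon. Among the compounds with values here, no measured step adds a second halogen to this ring; the known steps only exchange the one already present, and those exchanges were small. A change no larger than the scatter is therefore expected, in either direction. For compound 4 the expected step is a 1.1-fold lower number from compound 3 to compound 4 (0.05 log units; within the scatter), giving an estimate of 600 nM, between 250 nM and 1600 nM.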

Compound 4, half-maximal inhibitory concentration: 1630 nM
Compound 4: the middle estimate sits 2.7-fold (0.43 log units) below what was measured, outside the stated range (above it).
By their numbers in this assay, from the lowest: compound 1; then compounds 2 and 3 (each within the scatter of the next); then compound 4.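

In this assay, this fluoro occupies a new ring position, ortho to a large group, rather than exchanging one halogen for another, and it gives a step beyond the scatter: a 2.4-fold higher number from compound 3 to compound 4 (0.38 log units; beyond the scatter). The comparisons with the other two compounds show a 2.6-fold higher number from compound 2 to compound 4 (0.41 log units; beyond the scatter) and a 7.8-fold higher number from compound 1 to compound 4 (0.89 log units; beyond the scatter), leaving the 4-bromo-2-fluorophenyl compound with the highest number of the four. No measured evidence here accounts for this loss.

On these data alone, whether the loss belongs to fluoro or to any group at this position remains open. A methyl, a methoxy or an amine there would help separate those two readings.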